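Ethoxy to dimethylamino on the aryl ring

The source may hold more compounds than are shown below. What is called first, only, known or untested is meant among the compounds shown, and "the series" means these compounds.

Two members of the series have numbers in a functional assay on SGC-7901 cells (Homo sapiens) for antiproliferative activity, read by MTT assay, with a stated time of 48 h; a higher number here means a weaker inhibitor, a lower number a stronger inhibitor. Compound 1 `CCOc1ccccc1-c1nnc(SCc2ccc(Cl)nc2)o1` gives 10.3 ug/mL, while compound 2 `CCOc1ccc(-c2nnc(SCc3ccc(Cl)nc3)o2)cc1` gives 4.97 ug/mL, the lowest of the two and a gap beyond the scatter from compound 1. Compound 3 `CN(C)c1ccc(-c2nnc(SCc3ccc(Cl)nc3)o2)cc1` has not been measured; relative to compound 2 the change is dimethylamino in place of ethoxy on an aromatic carbon. For the measured compounds named here, no measured pair covers this kind of swap, so the expected step from compound 2 to compound 3 in this assay is a 1.1-fold lower number from compound 2 to compound 3 (0.04 log units; within the scatter), with no clear direction beyond the scatter. Compound 3 is estimated at 4.5 ug/mL, within 2 ug/mL to 10 ug/mL.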

Compound 3, half-maximal inhibitory concentration: 8.9 ug/mL
For compound 3 the middle estimate is 2.0-fold (0.30 log units) below the measured one, and the stated range covers the measured number.
By their numbers in this assay, from the lowest: compounds 2, 3 and 1 (each within the scatter of the next, the first and the last beyond it).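

In this assay the swap of ethoxy for dimethylamino on the aromatic carbon para to a large group gives a 1.8-fold higher number from compound 2 to compound 3 (0.25 log units; within the scatter) and so does not separate the two compounds. For the compounds shown here, this is the first pair that differs in one place only, and it shows that this position tolerates this exchange of one three-heavy-atom group for another. No measured data bear on why the two groups read alike here.

Going by these compounds, whether methoxy, a primary amine or a carboxylic acid at this position would give a step beyond the scatter remains open. A chain longer than ethoxy is also untested in the compounds shown.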